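Fluorophenyl position and tolerated concentration in the series

The source may hold more compounds than are shown below. What is called first, only, known or untested is meant among the compounds shown, and "the series" means these compounds.

Measured so far:
compound 1, `CC(=O)Nc1ccc2oc(-c3ccccc3F)c(O)c(=O)c2c1`: 171000 nM
compound 2, `CC(=O)Nc1ccc2oc(-c3cccc(F)c3)c(O)c(=O)c2c1`: 26500 nM
compound 3, `COc1c(-c2ccccc2F)oc2ccc(N)cc2c1=O`: 234000 nM

All three numbers come from an ADME assay on MT4 cells (Homo sapiens) for cytotoxicity, read by MTT assay, with a stated time of 4 days; a lower number here means that less compound is tolerated, a higher number that more compound is tolerated. Among the measured compounds shown here, the only change that is made twice is 3-fluorophenyl in place of 2-fluorophenyl on an aromatic carbon; within the core of compound 1 it gives a 6.5-fold lower number from compound 1 to compound 2 (0.81 log units; beyond the scatter). Compound 3 and compound 1 carry different cores, and the difference between the two cores is not broken down here. Compound 3 and compound 1 lie within the scatter of each other in this assay.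

Compound 4, `COc1c(-c2cccc(F)c2)oc2ccc(N)cc2c1=O`, is not yet measured. It differs from compound 3 by 3-fluorophenyl in place of 2-fluorophenyl on an aromatic carbon. The surroundings are not identical: in compound 1 the place is ortho to a hydroxy group, in compound 3 ortho to a methoxy group, so this is the same kind of change rather than the same change. The expectation is a step of about the earlier size, a 5.9-fold lower number from compound 3 to compound 4 (0.77 log units; beyond the scatter), because compound 1 gave a 6.5-fold lower number from compound 1 to compound 2 (0.81 log units; beyond the scatter). On that basis compound 4 is estimated at 40000 nM, with a range from 15000 nM to 120000 nM.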

Compound 4, half-maximal cytotoxic concentration: 113000 nM
Beside the measured number, compound 4's estimate is 2.8-fold (0.45 log units) below it; low and high end bracket the measured number.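

In this assay, 3-fluorophenyl in place of 2-fluorophenyl gives a 2.1-fold lower number from compound 3 to compound 4 (0.32 log units; beyond the scatter), so the direction of the change is the same on both cores. The size of the step does not carry over from one core to the other: the same change on two cores in this assay, a 6.5-fold lower number (0.81 log units; beyond the scatter) from compound 1 to compound 2 and a 2.1-fold lower number (0.32 log units; beyond the scatter) from compound 3 to compound 4, 3.1-fold (0.49 log units) apart, beyond the scatter of two such steps. Among the compounds shown here, with only two pairs, this shows that the direction held in both cases, but not that it is general across the series, and it does not show which difference between the two cores goes with the smaller step, as these cores differ in more than the hydroxy and methoxy groups.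

Still open, on these data alone, is how the same change behaves on a core that combines the methoxy group with the acetamide of compound 1, which would separate the two core differences. Also open, as far as these compounds go, is where 4-fluorophenyl or an unsubstituted phenyl would fall relative to the two fluorophenyl groups on either core.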